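The compounds below may be only part of what the source reports. "The series", "measured", "known", "first", "only" and "open" are said of these compounds alone.

Working notes on the series. Three compounds with one shared core have been run in a functional assay on the whole organism for inhibition, with Rattus norvegicus as the target; on this read-out lower numbers stand for an effect already at smaller amounts and higher numbers for an effect only at larger amounts of compound. Compound 1 `Cc1cc(/C=C/c2ccccc2OCC(O)CNC(C)C)on1` gives 0.006 mg/kg; compound 2 `Cc1cc(/C=C/c2ccccc2OCC(O)CNC2CC2)on1` gives 0.0091 mg/kg; compound 3 `Cc1cc(/C=C/c2ccccc2OCC(O)CNC(C)CCc2ccc(O)cc2)on1` gives 0.011 mg/kg. Compound 1 holds the lowest of the three numbers, but both other compounds sit within the scatter of it: a 1.5-fold higher number from compound 1 to compound 2 (0.18 log units; within the scatter) and a 1.8-fold higher number from compound 1 to compound 3 (0.26 log units; within the scatter). Both measured steps change the amine end of the molecule and leave the shared core as it is.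

Compound 4 `CC(C)NCC(O)COc1ccccc1/C=C/c1cc(Cl)no1` has not yet been measured in this assay. It differs from compound 1 by chloro in place of methyl on an aromatic carbon. For the measured compounds named here, no measured step touches this part of the molecule, and none therefore bears directly on the change. Going by the values given here, the only guidance is that the two changes made so far, a 1.5-fold higher number from compound 1 to compound 2 (0.18 log units; within the scatter) and a 1.8-fold higher number from compound 1 to compound 3 (0.26 log units; within the scatter), both stayed within the scatter. With no evidence for a direction, no step beyond the scatter is expected here either, but the range must be kept wide. The estimate for compound 4 in this assay is 0.006 mg/kg, expected between 0.002 mg/kg and 0.02 mg/kg. That estimate means an expected step of no change at the digits printed from compound 1 to compound 4 (within the scatter).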

Compound 4, dose for half-maximal effect: 0.0464 mg/kg
The estimate for compound 4 lay 7.7-fold (0.89 log units) below the measured number; measured number above the stated range.
By their numbers in this assay, from the lowest: compounds 1, 2 and 3 (each within the scatter of the next); then compound 4.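

In this assay, this aromatic carbon next to the ring nitrogen is sensitive to the group it carries: chloro in place of methyl, an exchange of one heavy atom for one heavy atom, gives a 7.7-fold higher number from compound 1 to compound 4 (0.89 log units; beyond the scatter). This is the only step shown that lies beyond the scatter, whereas both changes at the amine end stayed within it, so the position matters more in this read-out than the earlier compounds could indicate. Nothing available accounts for the size or direction of this step.

The compounds shown leave open whether other groups on this carbon, such as hydrogen, ethyl or methoxy, stay near compound 1 or fall nearer compound 4. Chloro appears here only with the isopropyl amine, so its effect alongside the cyclopropyl amine of compound 2 also remains open.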